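Removing a methoxy group from a potent Substance-P receptor ligand

The source may hold more compounds than are shown below. What is called first, only, known or untested is meant among the compounds shown, and "the series" means these compounds.

Measured so far:
compound 1, `Fc1ccc([C@@H]2NCCOC23COC[C@H](c2ccccc2)C3)cc1`, 99 nM
compound 2, `COc1ccc(C(F)(F)F)cc1[C@H]1COCC2(C1)OCCN[C@H]2c1ccc(F)cc1`, 1.3 nM

In an assay on CHO cells for displacement of a labelled ligand from Substance-P receptor (Homo sapiens) (on this read-out higher numbers stand for weaker inhibition and lower numbers for stronger inhibition), compound 2 gives the lowest of the two numbers. Compound 1, which carries an unsubstituted phenyl on the shared core, gives a markedly higher number, a gap far beyond the scatter. Compound 3, `Fc1ccc([C@@H]2NCCOC23COC[C@H](c2cccc(C(F)(F)F)c2)C3)cc1`, is not yet measured. It differs from compound 2 in one place: hydrogen in place of methoxy on an aromatic carbon, leaving only the trifluoromethyl group on that ring. Among the compounds with values here, no measured pair shows this exact change, so its size is unknown. Since compound 1 with a bare phenyl gives 99 nM while compound 2 gives 1.3 nM, removing one of the two substituents is expected to move the number upward, though not all the way back. Compound 3 is therefore expected to give 15 nM, between 4 nM and 60 nM, a weakening step a 12-fold higher number from compound 2 to compound 3 (1.06 log units; beyond the scatter).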

Compound 3, half-maximal inhibitory concentration: 30 nM
Compound 3: the middle estimate sits 2.0-fold (0.30 log units) below what was measured; the measured number falls inside the stated range.
By their numbers in this assay, from the lowest: compound 2; then compound 3; then compound 1.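

In this assay, the methoxy group ortho to a large group and para to a trifluoromethyl group carries real weight: replacing it with hydrogen gives a 23-fold higher number from compound 2 to compound 3 (1.36 log units; beyond the scatter) and so loses much of the strength of compound 2. The trifluoromethyl group on its own does less, since placing it on the bare phenyl ring gives a 3.3-fold lower number from compound 1 to compound 3 (0.52 log units; beyond the scatter) and this is a modest gain that is still beyond the scatter. Nothing available explains why the methoxy group counts for so much here.

The compounds shown leave open whether methoxy would count for as much on a ring without the trifluoromethyl group. They also leave open whether a hydroxyl group, an ethoxy group or a chlorine atom in the same place would keep the number as low as in compound 2.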